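A few compounds are considered here, and "the series" means these few. Any claim that something is new, unique, unknown or untested is made for them only; others in the source may bear on it.

The account follows two compounds measured in an assay on isolated protein for inhibition of ATP-dependent RNA helicase DDX3X (Homo sapiens), read by FRET, with stated times of 30 s and 40 min (on this read-out higher numbers stand for weaker inhibition and lower numbers for stronger inhibition), and another that awaits measurement. Compound 1 `COCCc1cn(-c2ccc(NC(=O)Nc3ccccc3C)cc2)nn1` gives 1000 nM in this assay, the highest of the two numbers recorded. Compound 2 `CCCCc1cn(-c2ccc(NC(=O)Nc3cc(OC4CCCC4)ccc3C)cc2)nn1` gives 140 nM in this assay, a lower number than compound 1 by a margin beyond the usual scatter. Going by the values given here, compound 2 differs from compound 1 in several places at once, so the two values show only that compound 2 is the stronger inhibitor of the pair. Compound 3 `Cc1ccccc1NC(=O)Nc1ccc(-n2cc(CCCN(C)C)nn2)cc1` differs from compound 1 in a single place: (dimethylamino)methyl in place of methoxy on a saturated chain carbon, two bonds along the chain from an aromatic carbon. Among the compounds with values here, no measured pair isolates this change, so its effect cannot be read from the data. The expected step is a 1.4-fold lower number from compound 1 to compound 3 (0.15 log units; within the scatter), a small shift that may not exceed the scatter, with stronger inhibition slightly favoured. Compound 3 is estimated to give 700 nM in this assay, with a range from 200 nM to 2500 nM.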

Compound 3, half-maximal inhibitory concentration: 2900 nM
Beside the measured number, compound 3's estimate is 4.1-fold (0.62 log units) below it; measured number outside the range, above it.
By their numbers in this assay, from the lowest: compound 2; then compound 1; then compound 3.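

Putting (dimethylamino)methyl in place of methoxy on a saturated chain carbon, two bonds along the chain from an aromatic carbon, gives a 2.9-fold higher number from compound 1 to compound 3 (0.46 log units; beyond the scatter) in this assay, towards weaker inhibition. Going by these compounds alone, this is the first comparison in the account that isolates a single change, and it shows that the number responds to what this chain carries, which the comparison of compound 1 with compound 2 could not show. No evidence at hand bears on why the number rises.

As far as these compounds go, it remains open whether the rise goes with the amine nitrogen or with the size of the group, a question that a pentyl chain on the core of compound 1 would address. Also open, from the compounds shown here alone, is how a carboxylic acid at the chain end would read, and whether the same change would shift the number on the core of compound 2.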